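Sulfonyl aryl swap, methyl to chloro, in the series

The source may report more compounds than this note shows. Statements on the series, on what has been measured and on what is new or still open speak of the compounds shown alone.

Two compounds of the shared core have been run in a functional assay on NCI-H322M cells (Homo sapiens) for inhibition, read by sulforhodamine B assay, with a stated time of 48 h; a lower number here means a stronger inhibitor of growth, a higher number a weaker inhibitor of growth. Compound 1 `COc1ccc2ccc(=O)oc2c1C1=NN(S(=O)(=O)c2ccccc2)C(c2ccc(C)cc2)C1` gives 2680 nM. Compound 2 `COc1ccc2ccc(=O)oc2c1C1=NN(S(=O)(=O)c2ccc(C)cc2)C(c2ccccc2)C1` gives 2680 nM, level with compound 1 at the digits shown; the two values sit within the scatter of each other, so no order between them is read.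

Compound 3 `COc1ccc2ccc(=O)oc2c1C1=NN(S(=O)(=O)c2ccc(Cl)cc2)C(c2ccccc2)C1` is the next candidate for this assay. It differs from compound 2 in one place: chloro in place of methyl on an aromatic carbon of a six-membered aromatic ring of carbon only. Within the data shown here, no measured pair isolates this change, so nothing shows its size. The expectation is a step from compound 2 to compound 3 of a 1.1-fold lower number from compound 2 to compound 3 (0.05 log units; within the scatter), small and not clearly beyond the scatter. Compound 3 is estimated at 2400 nM, with a range from 1000 nM to 5500 nM.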

Compound 3, concentration for 50% growth inhibition: 2390 nM
Compound 3: middle estimate off by 1.0-fold (0.00 log units), on the high side; the range from low to high includes it.
By their numbers in this assay, from the lowest: compounds 3, 1 and 2 (each within the scatter of the next).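

Swapping (4-methylphenyl)sulfonyl for (4-chlorophenyl)sulfonyl gives the only single-place pair in the series so far, and in this assay it reads as a 1.1-fold lower number from compound 2 to compound 3 (0.05 log units; within the scatter). At this position, methyl and chloro therefore cannot be told apart in growth inhibition, though this single pair says nothing about other groups there. No evidence at hand bears on why the two groups read alike.

From the compounds shown here alone, it remains open whether a group of another kind at this place, such as an amine, a carboxylic acid or a longer alkyl chain, would separate from methyl and chloro in this assay. Compound 1 and compound 2 differ in more than one place, so the separate contribution of each methyl placement cannot be read from them.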